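Amino to Dimethylamino on a Weakly Active Core

A few compounds are considered here, and "the series" means these few. Any claim that something is new, unique, unknown or untested is made for them only; others in the source may bear on it.

Measured compounds:
Compound 1, `Nc1nc2c(nc(Cl)n2COCCO)c(=O)[nH]1`: in a functional assay on L1210 cells (Mus musculus) for inhibition (a lower number here means a stronger inhibitor, a higher number a weaker inhibitor), compound 1 gives > 1000 ug/mL, which is a limit of the assay and not a number.
Compound 2, `Nc1nc2c(nc(N)n2COCCO)c(=O)[nH]1`: in this assay compound 2 gives 500 ug/mL.

Compound 2 holds the only number shown. The value of compound 1 is a limit, (the limit of > 1000 ug/mL in this assay, at which 1 of the 2 values shown sits). Among the measured compounds shown here, the one measured step, an at least 2.0-fold lower number from compound 1 to compound 2 (0.30 log units; that floor lies within the scatter), puts amino in place of chloro on an aromatic carbon. Compound 3, `CN(C)c1nc2c(=O)[nH]c(N)nc2n1COCCO`, differs from compound 2 in another way: dimethylamino in place of amino on an aromatic carbon. For the measured compounds named here, no measured step exchanges amino for dimethylamino, so the chloro-to-amino step offers no direct guide, and nothing among the measured compounds calls for a step beyond the scatter. In this assay the expected step is a 1.2-fold higher number from compound 2 to compound 3 (0.08 log units; within the scatter), within the scatter. The estimate for compound 3 is 600 ug/mL, with a range from 250 ug/mL to 1000 ug/mL.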

Compound 3, concentration for 50% inhibition: > 500 ug/mL
Compound 3 gave a limit, no number; the forecaster's own chance of this, stated with the estimate: 35%; the middle value lies beyond the limit too.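

In this assay compound 3 gives > 500 ug/mL, which is a limit of the assay and not a number. Putting dimethylamino, with 0 hydrogen-bond donors against 1 for amino, on this aromatic carbon brings no stronger inhibition, the step being a number no lower from compound 2 to compound 3 (the limit leaves the size open). The step between compound 1 and compound 3 cannot be read, and compound 2 remains the only one of the three with an actual number.

From the compounds shown here alone, how far the true value of compound 3 lies past its limit stays open, so any loss from this change has no known size. Also open, going by these compounds, is how methylamino, with a single methyl group on the nitrogen, or a hydroxyl group on this same carbon would fare in this assay.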